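Benzyl for the ester chain, at the assay limit

A few compounds are considered here, and "the series" means these few. Any claim that something is new, unique, unknown or untested is made for them only; others in the source may bear on it.

Measured in a functional assay on HCT-116 cells (Homo sapiens) for inhibition, read by sulforhodamine B assay, with a stated time of 48 h; on this read-out higher numbers stand for weaker inhibition and lower numbers for stronger inhibition:
Compound 1 `COc1ccc(C(O)(Cc2ccc(F)cc2)c2cccc3ccccc23)c(OC)c1OC`: > 20000 nM
Compound 2 `CCOC(=O)C(C)C(O)(c1ccc(OC)c(OC)c1OC)c1cccc2ccccc12`: > 20000 nM

Compound 2 gives only a limit, > 20000 nM, not a number. For the measured compounds named here, the series so far shows (the limit of > 20000 nM in this assay, at which 2 of the 2 values shown sit). Compound 3 `COc1ccc(C(O)(Cc2ccccc2)c2cccc3ccccc23)c(OC)c1OC` follows from benzyl in place of 1-(ethoxycarbonyl)ethyl on a saturated chain carbon bound to two aromatic carbons and an oxygen on a saturated carbon, with benzyl in place of 1-(ethoxycarbonyl)ethyl. Going by the values given here, the only measured step, a step that the two limits leave unreadable from compound 1 to compound 2, gives no size to build on. Compound 1, bearing 4-fluorobenzyl at that place, also gives only a limit, > 20000 nM. The expected step, a number no higher from compound 2 to compound 3 (the limit leaves the size open), is therefore none beyond the scatter in this assay. Compound 3 is estimated at 20000 nM, within an expected range of 9000 nM to 40000 nM.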

Compound 3, half-maximal inhibitory concentration: > 20000 nM
Compound 3: no number, only a limit (the forecaster's own chance of this, stated with the estimate: 80%); the middle value sits exactly at the limit.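

Compound 3 gives > 20000 nM, a limit and not a number, so no step among compound 1, compound 2 and compound 3 can be read: the limit of > 20000 nM in this assay, at which 3 of the 3 values shown sit.

The compounds shown leave open whether any group on that saturated chain carbon gives a measurable value.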